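Methyl on the amide-type nitrogen: compound 3 to compound 4

The source may hold more compounds than are shown below. What is called first, only, known or untested is meant among the compounds shown, and "the series" means these compounds.

Compound 3 `CCNC(=O)N1CCN(C(=S)SCc2cn(Cc3ccc(F)cc3)nn2)CC1` holds the higher of the two numbers seen in a functional assay on SMMC-7721 cells (Homo sapiens) for cytotoxicity, read by MTT assay, with a stated time of 72 h (a lower number here means a stronger inhibitor, a higher number a weaker inhibitor), at 44400 nM. Compound 2 `CCN(C)C(=O)N1CCN(C(=S)SCc2cn(Cc3ccccc3F)nn2)CC1` sits nearest, at 19700 nM. Compound 1 `CCNC(=O)N1CCN(C(=S)SCc2cn(Cc3ccccc3F)nn2)CC1` gives only a limit of this assay, > 128000 nM. Compound 4 `CCN(C)C(=O)N1CCN(C(=S)SCc2cn(Cc3ccc(F)cc3)nn2)CC1` differs from compound 3 by methyl in place of hydrogen on an amide-type nitrogen. The same change has been measured once, an at least 6.4-fold lower number from compound 1 to compound 2 (0.81 log units; beyond the scatter), but because its starting point is itself a limit of > 128000 nM in this assay, at which 1 of the 3 values shown sits, the true size of that step is open. The other step in the set, an at least 2.8-fold lower number from compound 1 to compound 3 (0.45 log units; beyond the scatter), runs in the same direction and rests on the same limit. A lowering of roughly that size is therefore expected, a 4.9-fold lower number from compound 3 to compound 4 (0.69 log units; beyond the scatter). Compound 4 is estimated at 9000 nM, between 3000 nM and 30000 nM.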

Compound 4, half-maximal inhibitory concentration: 23700 nM
For compound 4 the middle estimate is 2.6-fold (0.42 log units) below the measured one; the range from low to high includes it.
By their numbers in this assay, from the lowest: compounds 2, 4 and 3 (each within the scatter of the next, the first and the last beyond it). At a limit, above all of these: compound 1.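

In this assay, methyl in place of hydrogen on the amide-type nitrogen stays within the scatter when the 4-fluorophenyl group is present, a 1.9-fold lower number from compound 3 to compound 4 (0.27 log units; within the scatter), so the size of this step depends on the core: the same change on two cores in this assay, an at least 6.4-fold lower number (0.81 log units; beyond the scatter) from compound 1 to compound 2 and a 1.9-fold lower number (0.27 log units; within the scatter) from compound 3 to compound 4, at least 3.4-fold (0.54 log units) apart, beyond the scatter of two such steps

With methyl already on that nitrogen, 4-fluorophenyl in place of 2-fluorophenyl also stays within the scatter, a 1.2-fold higher number from compound 2 to compound 4 (0.08 log units; within the scatter), and this change likewise differs between cores: the same change on two cores in this assay, an at least 2.8-fold lower number (0.45 log units; beyond the scatter) from compound 1 to compound 3 and a 1.2-fold higher number (0.08 log units; within the scatter) from compound 2 to compound 4, at least 3.4-fold (0.54 log units) apart, beyond the scatter of two such steps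

Compound 1 gives only a limit, > 128000 nM, and the larger step of each pair starts from it.

Still open, going by these compounds, is whether a longer chain in place of the methyl on the amide-type nitrogen gives a step beyond the scatter. Also open, on these data alone, is what chlorine or methoxy in place of the fluorine would give.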